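This account rests on a few compounds, and the source may have more. Where it says the series, first, only, none or still open, it means among the compounds named here.

Measured so far in a functional assay on HOP-62 cells (Homo sapiens) for inhibition, read by sulforhodamine B assay, with a stated time of 48 h; a higher number here means a weaker inhibitor of growth, a lower number a stronger inhibitor of growth:
compound 1 `Nc1cc(N)c2nc(-c3ccccc3)c(NCc3ccc(Cl)c(Cl)c3)nc2c1` gives 15800 nM
compound 2 `COc1ccc(CNc2nc3cc(N)cc(N)c3nc2-c2ccccc2)cc1OC` gives 18200 nM

Among the compounds with values here, compound 2 stands at the highest of these two numbers, yet its nearest neighbour, compound 1, is so close that the only measured step, a 1.2-fold higher number from compound 1 to compound 2 (0.06 log units; within the scatter), is within the scatter. Compound 3 `COc1cc(CNc2nc3cc(N)cc(N)c3nc2-c2ccccc2)cc(OC)c1OC` differs from compound 2 by methoxy in place of hydrogen on an aromatic carbon. Within the data shown here, the one step that bears on this change, again on the same phenyl ring, gave no movement beyond the scatter, so none is expected here either. Compound 3 is therefore estimated at 19000 nM, in the range 8000 nM to 45000 nM, an expected step of a 1.0-fold higher number from compound 2 to compound 3 (0.02 log units; within the scatter).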

Compound 3, concentration for 50% growth inhibition: 17000 nM
Beside the measured number, compound 3's estimate is 1.1-fold (0.05 log units) above it; measured number inside the range.
By their numbers in this assay, from the lowest: compounds 1, 3 and 2 (each within the scatter of the next).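

In this assay, methoxy in place of hydrogen on an aromatic carbon, ortho to a methoxy group and meta to a large group, brings a 1.1-fold lower number from compound 2 to compound 3 (0.03 log units; within the scatter) as its result. The earlier step exchanged one set of groups for another, whereas this one adds a group where compound 2 carries only hydrogen, and the reading of compound 3 still does not separate from that of compound 2.

Going by these compounds, whether an amine, a carboxylic acid or a longer chain in this place would move the number stays open. Nothing available explains why this addition leaves the number within the scatter.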